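Urea in place of thiourea on the ring nitrogen

The compounds below may be only part of what the source reports. "The series", "measured", "known", "first", "only" and "open" are said of these compounds alone.

Compound 3 `NC(=O)c1c(NC(=O)c2ccccc2Cl)sc2c1CCN(C(=S)Nc1ccccc1F)C2` gives 28700 nM in a functional assay on HeLa cells (Homo sapiens) for antiproliferative activity, with a stated time of 24 h; a lower number here means a stronger inhibitor, a higher number a weaker inhibitor. Among the three compounds measured so far it holds the second highest number. Its nearest neighbour is compound 2 `NC(=O)c1c(NC(=O)c2ccccc2Cl)sc2c1CCN(Cc1cc(Cl)cc(Cl)c1)C2`, which gives 19600 nM in this assay, and the gap is a 1.5-fold higher number from compound 2 to compound 3 (0.17 log units; within the scatter). The furthest is compound 1 `NC(=O)c1c(NC(=O)c2ccccc2Cl)sc2c1CCNC2`, which gives 45000 nM in this assay, and that gap is a 1.6-fold lower number from compound 1 to compound 3 (0.20 log units; within the scatter). Both gaps lie within the scatter, so no order can be read between these three.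

Compound 4 `NC(=O)c1c(NC(=O)c2ccccc2Cl)sc2c1CCN(C(=O)Nc1c(Cl)cccc1Cl)C2` differs from compound 3 by a group of 11 heavy atoms (7 carbon, 1 nitrogen, 1 oxygen, 2 chlorine; one six-membered aromatic ring of carbon only) in place of a group of 10 heavy atoms (7 carbon, 1 nitrogen, 1 fluorine, 1 sulfur; one six-membered aromatic ring of carbon only), on an amine nitrogen in a ring. The measured steps that bear on this position are those that alter the same ring nitrogen: a 2.3-fold lower number from compound 1 to compound 2 (0.36 log units; beyond the scatter), a modest step and the only one beyond the scatter, and a 1.6-fold lower number from compound 1 to compound 3 (0.20 log units; within the scatter), within the scatter. The comparison of the two substituted compounds, a 1.5-fold higher number from compound 2 to compound 3 (0.17 log units; within the scatter), is also within the scatter. Changes at this nitrogen have so far moved the number by little, and nothing in hand separates a urea from a thiourea there. The step expected is therefore a 1.1-fold lower number from compound 3 to compound 4 (0.06 log units; within the scatter), in either direction not beyond the scatter. Compound 4 is estimated at 25000 nM, with a range from 10000 nM to 60000 nM.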

Compound 4, half-maximal inhibitory concentration: 27200 nM
Compound 4: middle estimate off by 1.1-fold (0.04 log units), on the low side; measured number inside the range.
By their numbers in this assay, from the lowest: compounds 2, 4, 3 and 1 (each within the scatter of the next, the first and the last beyond it).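

Placing (2,6-dichlorophenyl)carbamoyl on the amine nitrogen in a ring, in place of the thiourea group, gives a 1.1-fold lower number from compound 3 to compound 4 (0.02 log units; within the scatter) in this assay, so this urea and the thiourea of compound 3 cannot be told apart. Among the compounds shown here, the same group gives a 1.4-fold higher number from compound 2 to compound 4 (0.14 log units; within the scatter) and a 1.7-fold lower number from compound 1 to compound 4 (0.22 log units; within the scatter), which shows that a third kind of substituent on this nitrogen also stays within the scatter of both the benzyl compound and the unsubstituted compound, leaving a 2.3-fold lower number from compound 1 to compound 2 (0.36 log units; beyond the scatter) as the only step here beyond it. Compound 3 and compound 4 differ in both the sulfur or oxygen of the linking group and the halogens on the ring. The near-identical numbers cannot be credited to either change alone, and they could reflect two opposing effects or none.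

No measurement available here explains why these groups score alike. A urea and a thiourea sharing one identical aromatic ring remain to be compared, as do an amine or a carboxylic acid on a longer chain at this nitrogen.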